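Shortening the chain on a weakly active stomach series

The compounds below may be only part of what the source reports. "The series", "measured", "known", "first", "only" and "open" are said of these compounds alone.

Compound 1 `Cc1ccc(=S)n(CCC(=N)S)n1` and compound 2 `N=C(S)CCn1nc(-c2ccccc2)ccc1=S` were both tested in a functional assay on the whole organism (stomach) with Rattus norvegicus as the target; on this read-out lower numbers stand for an effect already at smaller amounts and higher numbers for an effect only at larger amounts of compound. Compound 1 gives 100 mg/kg. Compound 2 gives 73.4 mg/kg. Among the compounds with values here, the only step measured so far is a 1.4-fold lower number from compound 1 to compound 2 (0.13 log units; within the scatter). Compound 3 `N=C(S)CCCCn1nc(-c2ccccc2)ccc1=O` stands apart from these two. In this assay compound 3 reaches only the limit of the assay, > 100 mg/kg, not a number; (the limit of > 100 mg/kg in this assay, at which 1 of the 3 values shown sits). Compound 4 `N=C(S)CCCn1nc(-c2ccccc2)ccc1=O` is the next compound: a group of 3 heavy atoms (1 carbon, 1 nitrogen, 1 sulfur; no ring) in place of a group of 4 heavy atoms (2 carbon, 1 nitrogen, 1 sulfur; no ring), on a saturated chain carbon, three bonds along the chain from an aromatic nitrogen. Within the data shown here, no measured step touches a change of this kind, and the one known step, between the methyl and phenyl compounds, lies within the scatter, so there is nothing to build a direction on. Compound 4 is therefore expected to stay near the limit, with the step of a number no higher from compound 3 to compound 4 (the limit leaves the size open) estimated as no more than scatter. Compound 4 is estimated at 100 mg/kg, between 50 mg/kg and 200 mg/kg.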

Compound 4, dose for half-maximal effect: 31.9 mg/kg
Beside the measured number, compound 4's estimate is 3.1-fold (0.50 log units) above it; the measured number lies below the stated range.
By their numbers in this assay, from the lowest: compound 4; then compounds 2 and 1 (each within the scatter of the next).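

Shortening the chain gives, in this assay, an at least 3.1-fold lower number from compound 3 to compound 4 (0.49 log units; beyond the scatter), the first step shown that lies beyond the scatter. This saturated chain, three bonds along from the aromatic nitrogen, therefore responds to a change where the swap of methyl for phenyl showed no clear effect. The true size of the step stays open, since compound 3 has only a limit: the limit of > 100 mg/kg in this assay, at which 1 of the 4 values shown sits.

The compounds shown do not tell why the shorter chain gives the lower number. They also leave open how an even shorter chain on the core of compound 4 would read, or an amine or a carboxylic acid at the chain end.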